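Swapping the piperidine on compound 2 for methylpiperazine

The source may hold more compounds than are shown below. What is called first, only, known or untested is meant among the compounds shown, and "the series" means these compounds.

The measured values in a functional assay on MCF7 cells (Homo sapiens) for inhibition, read by MTT assay, with a stated time of 48 h (on this read-out lower numbers stand for stronger inhibition and higher numbers for weaker inhibition), are these.
Compound 1 (`COc1ccc(-c2nc3c(c(-c4ccccc4)nn3-c3ccccc3)c(-c3ccc(N4CCCCC4)cc3)c2C#N)cc1`) reads (2760 nM)
Compound 2 (`N#Cc1c(-c2ccccc2)nc2c(c(-c3ccccc3)nn2-c2ccccc2)c1-c1ccc(N2CCCCC2)cc1`) reads (27000 nM)
Compound 3 (`O=C(C=CNc1cc(-c2ccccc2)nn1-c1ccccc1)c1cccs1`) reads (15400 nM)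

Compound 2 lies within the scatter of compound 3 and clearly apart from compound 1. Compound 4 (`CN1CCN(c2ccc(-c3c(C#N)c(-c4ccccc4)nc4c3c(-c3ccccc3)nn4-c3ccccc3)cc2)CC1`) has 4-methylpiperazin-1-yl in place of piperidin-1-yl on an aromatic carbon. Within the data shown here, no measured step touches that place. The only one available, a 9.8-fold higher number from compound 1 to compound 2 (0.99 log units; beyond the scatter), is hydrogen in place of methoxy elsewhere on the shared core, so it shows that the series can move but gives no size for this change. For compound 4 the expected step is a 1.7-fold lower number from compound 2 to compound 4 (0.23 log units; within the scatter) in this assay and no step beyond the scatter is expected. Compound 4 is estimated at 16000 nM in this read-out, with an expected range from 5000 nM to 40000 nM around that figure.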

Compound 4, half-maximal inhibitory concentration: 14300 nM
Estimate against measurement, compound 4: 1.1-fold (0.05 log units) above, within the range that was stated.
By their numbers in this assay, from the lowest: compound 1; then compounds 4, 3 and 2 (each within the scatter of the next).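

In this assay, among these compounds, this is the first direct reading of the position on the aromatic carbon para to a large group: 4-methylpiperazin-1-yl in place of piperidin-1-yl gives a 1.9-fold lower number from compound 2 to compound 4 (0.28 log units; within the scatter) and stays within the scatter. This pair therefore shows that the added ring nitrogen and methyl leave the read-out indistinguishable here, whereas the earlier methoxy step lay elsewhere on the shared core. No measured evidence bears on this result.

Going by these compounds, whether morpholin-4-yl or a carboxylic acid at this place would move the number beyond the scatter remains open. So does whether 4-methylpiperazin-1-yl behaves the same alongside the methoxy group of compound 1.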